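A few compounds are considered here, and "the series" means these few. Any claim that something is new, unique, unknown or untested is made for them only; others in the source may bear on it.

Measured compounds:
- compound 1 `Cc1cccc(-c2ccc(COCCCCCN3C[C@H](O)[C@@H](O)[C@H](O)[C@H]3CO)cc2)c1`: 100 nM
- compound 2 `OC[C@@H]1[C@@H](O)[C@H](O)[C@@H](O)CN1CCCCCOCc1ccc(-c2ccccc2F)cc1`: 75 nM
- compound 3 `OC[C@@H]1[C@@H](O)[C@H](O)[C@@H](O)CN1CCCCCOCc1ccc(-c2cc(C(F)(F)F)cc(C(F)(F)F)c2)cc1`: 20 nM

In an assay on isolated protein for inhibition of ceramide glucosyltransferase (Homo sapiens) (a higher number here means a weaker inhibitor, a lower number a stronger inhibitor), compound 2 gives 75 nM and stands second highest of the three numbers; compound 1 sits nearest at 100 nM, a gap within the scatter, while compound 3 at 20 nM lies furthest off, beyond the scatter. The unmeasured compound 4 `OC[C@@H]1[C@@H](O)[C@H](O)[C@@H](O)CN1CCCCCOCc1ccc(-c2ccc(F)nc2)cc1` differs from compound 2 in one place: 6-fluoropyridin-3-yl in place of 2-fluorophenyl on an aromatic carbon. Going by the values given here, only one measured step changes this same terminal ring, a 1.3-fold lower number from compound 1 to compound 2 (0.12 log units; within the scatter), and it stayed within the scatter. Among the compounds with values here, the swap to compound 3 shows that this ring can move the number beyond the scatter, but no step bearing a ring nitrogen is available. Compound 4 keeps the fluorine and adds a single ring nitrogen, so a step of modest size is expected in this assay, most likely toward a slightly higher number but possibly none beyond the scatter, which a 1.5-fold higher number from compound 2 to compound 4 (0.17 log units; within the scatter) expresses. Compound 4 is therefore estimated at 110 nM, with a range from 40 nM to 300 nM.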

Compound 4, half-maximal inhibitory concentration: 750 nM
For compound 4 the middle estimate is 6.8-fold (0.83 log units) below the measured one, outside the stated range (above it).
By their numbers in this assay, from the lowest: compound 3; then compounds 2 and 1 (each within the scatter of the next); then compound 4.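

In this assay, going by these compounds alone, the terminal ring on this aromatic carbon, para to a large group, turns out to be far less tolerant than the earlier compounds suggested: a 10-fold higher number from compound 2 to compound 4 (1.00 log units; beyond the scatter) and a 7.5-fold higher number from compound 1 to compound 4 (0.88 log units; beyond the scatter) are both beyond the scatter, whereas the only earlier step between two such rings stayed within it. The 6-fluoropyridin-3-yl ring is the only one shown with a hetero atom in the ring, and so the first to bring a hydrogen-bond acceptor, and this is the change that coincides with the higher number. Nothing shown gives a reason for this rise.

The step from 2-fluorophenyl also moves the fluorine, so the compounds shown do not separate that move from the ring nitrogen. A 4-fluorophenyl ring, an unsubstituted pyridin-3-yl ring or a pyrimidine ring could help tell these apart.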